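A few compounds are considered here, and "the series" means these few. Any claim that something is new, unique, unknown or untested is made for them only; others in the source may bear on it.

Measured so far:
Compound 1, `O=C(NCC(=O)N1[C@@H](c2cccc(O)c2)CC[C@H]1C(=O)O)[C@@H](S)Cc1ccccc1`, with 2.4 nM.
Compound 2, `O=C(NCC(=O)N1[C@@H](c2cccc(O)c2)CC[C@H]1C(=O)O)[C@@H](S)Cc1cccc(O)c1`, with 4.3 nM.

Of the compounds shown here, two have been measured in an assay on isolated protein for inhibition of Neprilysin (Oryctolagus cuniculus); a higher number here means a weaker inhibitor, a lower number a stronger inhibitor. Compound 1 gives 2.4 nM. Compound 2 gives 4.3 nM, which is the higher of the two numbers, but the step of a 1.8-fold higher number from compound 1 to compound 2 (0.25 log units; within the scatter) lies within the scatter, so the two compounds cannot be told apart on these data.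

Compound 3, `O=C(NCC(=O)N1[C@@H](c2cccc(O)c2)CC[C@H]1C(=O)O)C(S)Cc1ccc(F)cc1`, is the next compound. Compared with compound 2 it carries a group of 10 heavy atoms (8 carbon, 1 fluorine, 1 sulfur; one six-membered aromatic ring of carbon only) in place of a group of 10 heavy atoms (8 carbon, 1 oxygen, 1 sulfur; one six-membered aromatic ring of carbon only), on a carbonyl carbon. For the measured compounds named here, the only measured step that bears on this change is the one from compound 1 to compound 2, in which a hydroxy entered in place of a hydrogen on an aromatic carbon and the number moved by a 1.8-fold higher number from compound 1 to compound 2 (0.25 log units; within the scatter), within the scatter. Going by the values given here, for the fluorine that enters there is no measured step at all. On this basis the step is expected to be small: a 1.4-fold lower number from compound 2 to compound 3 (0.16 log units; within the scatter), with no clear direction. Compound 3 is therefore estimated to give 3 nM in this assay, in the range 1 nM to 10 nM.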

Compound 3, half-maximal inhibitory concentration: 5.3 nM
Estimate against measurement, compound 3: 1.8-fold (0.25 log units) below; the measured number falls inside the stated range.
By their numbers in this assay, from the lowest: compounds 1, 2 and 3 (each within the scatter of the next, the first and the last beyond it).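

Between the hydroxy-bearing and fluorine-bearing groups on the carbonyl carbon the step is a 1.2-fold higher number from compound 2 to compound 3 (0.09 log units; within the scatter), so in this assay these two groups cannot be told apart. Against the group that carries neither substituent, the fluorine-bearing group gives a 2.2-fold higher number from compound 1 to compound 3 (0.34 log units; beyond the scatter), the only step at this position that passes the scatter, and a modest one. Nothing available explains this result.

The group in compound 3 has no defined stereocentre, whereas the group in compound 2 has one, so the compounds shown do not separate the effect of that stereocentre from the effect of the ring substituent. They also leave open how a chlorine, a methoxy group or an amine on the aromatic ring would compare with the fluorine and the hydroxy.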